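The source may hold more compounds than are shown below. What is called first, only, known or untested is meant among the compounds shown, and "the series" means these compounds.

Compound 1 `CN1CCN(c2ccc(Nc3ncc4nc(Nc5ccc(F)cc5)n([C@H]5CCCNC5)c4n3)cc2)CC1` was made, and in a functional assay on A-431 cells (Homo sapiens) for antiproliferative activity, read by MTT assay, with a stated time of 72 h (on this read-out higher numbers stand for weaker inhibition and lower numbers for stronger inhibition), compound 1 gives "not determined" (no result reported). Going by the values given here, compound 2 `CN1CCN(c2ccc(Nc3ncc4nc(Nc5ccc(F)cc5)n([C@H]5CCCN(C(=O)CO)C5)c4n3)cc2)CC1` is the one measured compound of this pair: in this assay compound 2 gives 3000 nM, the only number to set it against, so nothing else places it. Compound 3 `CN1CCN(c2ccc(Nc3ncc4nc(Nc5ccc(F)cc5)n(-c5cccc(NC(=O)CO)c5)c4n3)cc2)CC1` carries 3-(((hydroxymethyl)carbonyl)amino)phenyl in place of 1-((hydroxymethyl)carbonyl)piperidin-3-yl on an aromatic nitrogen. Among the compounds with values here, no step between measured compounds is available for such a change, so the expected step from compound 2 to compound 3, a 1.5-fold lower number from compound 2 to compound 3 (0.18 log units; within the scatter), is held small and barely beyond the scatter, with the direction uncertain. For compound 3 the estimate in this assay is 2000 nM, expected to fall between 400 nM and 10000 nM.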

Compound 3, half-maximal inhibitory concentration: 1670 nM
Compound 3: the middle estimate sits 1.2-fold (0.08 log units) above what was measured; the measured number falls inside the stated range.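

At this aromatic nitrogen, 3-(((hydroxymethyl)carbonyl)amino)phenyl in place of 1-((hydroxymethyl)carbonyl)piperidin-3-yl gives a 1.8-fold lower number from compound 2 to compound 3 (0.25 log units; within the scatter) in this assay and so does not separate the two compounds. The same hydroxymethyl carbonyl unit can therefore sit on either ring, the six-membered non-aromatic ring with its defined stereocentre or the aromatic carbon ring, with no difference beyond the scatter. No measurement shown accounts for this result. Still open, on these data alone, is whether a free amine or a carboxylic acid in place of the hydroxymethyl carbonyl unit, or a longer chain on the phenyl ring, would move the number beyond the scatter.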